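The source may report more compounds than this note shows. Statements on the series, on what has been measured and on what is new or still open speak of the compounds shown alone.

Measured in a functional assay on CFPAC-1 cells (Homo sapiens) for antiproliferative activity, read by MTT assay, with a stated time of 72 h; a higher number here means a weaker inhibitor, a lower number a stronger inhibitor:
- Compound 1 `COc1ccccc1-c1cn(C[C@H](O)[C@H]2OC(=O)C(OCc3ccccc3)=C2OCc2ccccc2)nn1`: > 100000 nM, a limit of the assay
- Compound 2 `O=C1O[C@H]([C@@H](O)Cn2cc(-c3cc(F)cc(F)c3)nn2)C(OCc2ccccc2)=C1OCc1ccccc1`: 62400 nM
- Compound 3 `Cc1ccc(S(=O)(=O)NCc2cn(C[C@H](O)[C@H]3OC(=O)C(OCc4ccccc4)=C3OCc3ccccc3)nn2)cc1`: 68000 nM

Within the data shown here, compound 3 gives 68000 nM, and the only other value that is a number lies close to it, the step being a 1.1-fold higher number from compound 2 to compound 3 (0.04 log units; within the scatter). Compound 4 `O=C1O[C@H]([C@@H](O)Cn2ccnn2)C(OCc2ccccc2)=C1OCc1ccccc1` has yet to be measured in this assay. It differs from compound 3 as follows: hydrogen in place of (((4-methylphenyl)sulfonyl)amino)methyl on an aromatic carbon. In words, hydrogen stands in place of (((4-methylphenyl)sulfonyl)amino)methyl on an aromatic carbon.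

Two measured steps change the group on this same carbon: an at least 1.6-fold lower number from compound 1 to compound 2 (0.20 log units; that floor lies within the scatter) and an at least 1.4-fold lower number from compound 1 to compound 3 (0.16 log units; that floor lies within the scatter). Both are floors, and neither puts hydrogen there, so the data give no direct measure of this change. Among the measured compounds shown here, with a 1.1-fold higher number from compound 2 to compound 3 (0.04 log units; within the scatter) as the one step between two numbers, no large change is expected. The expected step is a 1.3-fold higher number from compound 3 to compound 4 (0.10 log units; within the scatter), with any drift toward a higher number. Compound 4 is estimated at 85000 nM. The expected range for compound 4 runs from 35000 nM to 200000 nM.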

Compound 4, half-maximal inhibitory concentration: > 100000 nM
Compound 4: no number, only a limit; the forecaster's own chance of this, stated with the estimate: 40%; at least 1.1-fold (0.07 log units) between middle value and limit.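

In this assay compound 4, which carries only hydrogen on this aromatic carbon of the five-membered ring, gives > 100000 nM, a limit of the assay. The readable steps to it are an at least 1.4-fold higher number from compound 3 to compound 4 (0.16 log units; that floor lies within the scatter) and an at least 1.6-fold higher number from compound 2 to compound 4 (0.20 log units; that floor lies within the scatter), while the step from compound 1 cannot be read. Hydrogen thus joins 2-methoxyphenyl at the limit, leaving 3,5-difluorophenyl and (((4-methylphenyl)sulfonyl)amino)methyl as the only groups here with a number, though these floors lie within the scatter and do not firmly separate the two pairs: the limit of > 100000 nM in this assay, at which 2 of the 4 values shown sit.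

The compounds shown leave open whether any group on this carbon can give a number far lower than those of compound 2 and compound 3. An amine, a carboxylic acid or a longer alkyl chain at this position would test that.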